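Replacing the cyanobenzyl group with cyclobutylmethyl

The source may hold more compounds than are shown below. What is called first, only, known or untested is meant among the compounds shown, and "the series" means these compounds.

Compound 1 `COc1cc(N)c(Cl)cc1NC(=O)C1CCN(Cc2cccc(C)c2)CC1`: 2.4 mg/kg
Compound 2 `COc1cc(N)c(Cl)cc1NC(=O)C1CCN(C/C=C/c2ccccc2)CC1`: > 10 mg/kg
Compound 3 `COc1cc(N)c(Cl)cc1NC(=O)C1CCN(Cc2cccc(C#N)c2)CC1`: > 4 mg/kg

In a functional assay on the whole organism for antagonist activity, with Mus musculus as the target (on this read-out lower numbers stand for an effect already at smaller amounts and higher numbers for an effect only at larger amounts of compound), compound 3 gives only a limit, (the limit of > 4 mg/kg in this assay, at which 1 of the 3 values shown sits), so its true position is not known. Compound 4 `COc1cc(N)c(Cl)cc1NC(=O)C1CCN(CC2CCC2)CC1` differs from compound 3 by cyclobutyl in place of 3-cyanophenyl on a saturated chain carbon bound to an amine nitrogen in a ring. For the measured compounds named here, two measured steps bear on this change. The step of an at least 4.1-fold higher number from compound 1 to compound 2 (0.61 log units; beyond the scatter) shows that changing the group on that carbon can weaken the effect clearly; the step of an at least 1.6-fold higher number from compound 1 to compound 3 (0.22 log units; that floor lies within the scatter) is a limit that stays within the scatter, and the step that the two limits leave unreadable from compound 2 to compound 3 cannot be read. Since compound 3 starts at a limit, no step beyond the scatter can be read for compound 4 in this assay. Compound 4 is therefore expected to give 8 mg/kg, with a range from 2 mg/kg to 30 mg/kg. This estimate corresponds to an expected step that the limit leaves unreadable from compound 3 to compound 4.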

Compound 4, dose for half-maximal effect: > 10 mg/kg
Compound 4: no number, only a limit (the forecaster's own chance of this, stated with the estimate: 60%); middle value at least 1.2-fold (0.09 log units) away from the limit.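

In this assay compound 4 gives only a limit: the limit of > 10 mg/kg in this assay, at which 2 of the 4 values shown sit. Cyclobutyl in place of 3-methylphenyl brings an at least 4.1-fold higher number from compound 1 to compound 4 (0.61 log units; beyond the scatter), so this position loses the value of compound 1 with a non-aromatic ring as well as with 2-phenylethenyl. Among the compounds shown, only compound 1 gives a number, and the steps from compound 2 and from compound 3 to compound 4 cannot be read.

Where the true value of compound 4 lies remains open. So does whether cyclohexyl or an unsubstituted phenyl on that saturated chain carbon would give a number.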